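A few compounds are considered here, and "the series" means these few. Any claim that something is new, unique, unknown or untested is made for them only; others in the source may bear on it.

Compound 2 `COc1c(C)cnc(CN2CC(=O)N(CCCC(C)C)c3c(Cl)nc(N)nc32)c1C` gives 1650 nM in a functional assay on BT-474 cells (Homo sapiens) for inhibition (a higher number here means a weaker inhibitor, a lower number a stronger inhibitor), the highest of the three numbers recorded. Compound 1 `COc1c(C)cnc(CN2c3nc(N)nc(Cl)c3NC(=O)[C@@H]2C)c1C` gives 470 nM and compound 3 `COc1ccnc(CN2CC(=O)N(CC(C)C)c3c(Cl)nc(N)nc32)c1OC` gives 30 nM; both gaps to compound 2 lie beyond the scatter, so compound 2 is the weakest inhibitor among the three measured. Compound 4 `COc1c(C)cnc(CN2CC(=O)N(CCN3CCCC3)c3c(Cl)nc(N)nc32)c1C` has not yet been measured in this assay. The change from compound 2 to compound 4 is pyrrolidin-1-yl in place of isobutyl on a saturated chain carbon, two bonds along the chain from an amide-type nitrogen in a ring. For the measured compounds named here, compounds 1 and 3 differ from compound 2 in more than one place, so no measured pair isolates this change. The step from compound 2 to compound 4 is expected to be a 2.1-fold lower number from compound 2 to compound 4 (0.31 log units; beyond the scatter), a modest lowering that may not clear the scatter. Compound 4 is therefore estimated at 800 nM, within a range from 200 nM to 3200 nM.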

Compound 4, half-maximal inhibitory concentration: 520 nM
Beside the measured number, compound 4's estimate is 1.5-fold (0.19 log units) above it, and the stated range covers the measured number.
By their numbers in this assay, from the lowest: compound 3; then compounds 1 and 4 (each within the scatter of the next); then compound 2.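

At this place on the chain, pyrrolidin-1-yl in place of isobutyl gives a 3.2-fold lower number from compound 2 to compound 4 (0.50 log units; beyond the scatter) in this assay, the first reading of a single change among these compounds. It shows that the number responds to the group carried here, and that a ring with one nitrogen is tolerated at this place. Nothing given here accounts for the step. As far as these compounds go, what stays open is whether the ring or the nitrogen carries it: cyclopentyl or an open-chain diethylamino group at the same place would separate the two.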